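Methyl on the core: cytotoxicity notes for the series

The compounds below may be only part of what the source reports. "The series", "measured", "known", "first", "only" and "open" are said of these compounds alone.

Measured compounds:
Compound 1, `CCCSc1nc(Cc2c(F)cccc2Cl)cc(=O)[nH]1`. In an ADME assay on MT4 cells (Homo sapiens) for activation, read by MTT assay (on this read-out lower numbers stand for higher toxicity in this test and higher numbers for lower toxicity in this test), compound 1 gives > 80000 nM, a limit of the assay.
Compound 2, `CCCSc1nc(Cc2c(F)cccc2Cl)c(C)c(=O)[nH]1`. In this assay compound 2 gives > 76000 nM, likewise a limit.
Compound 3, `CC(C)Sc1nc(C(C)c2c(F)cccc2Cl)cc(=O)[nH]1`. In this assay compound 3 gives > 75000 nM, also a limit.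

Compound 1 and compound 2 differ by methyl in place of hydrogen on an aromatic carbon. The step that the two limits leave unreadable from compound 1 to compound 2 cannot be sized because the limit of > 80000 nM in this assay, at which 1 of the 3 values shown sits, and the limit of > 76000 nM in this assay, at which 1 of the 3 values shown sits, cap both readings. The difference between the cores of compound 1 and compound 3 is not broken down here.

Compound 4, `Cc1c(C(C)c2c(F)cccc2Cl)nc(SC(C)C)[nH]c1=O`, is not yet measured; it differs from compound 3 by methyl in place of hydrogen on an aromatic carbon. This is the same kind of change as from compound 1 to compound 2, not the same: here the place is ortho to a large group rather than to a group of 9 heavy atoms, and para to an isopropylsulfanyl group rather than a propylsulfanyl group. Compound 3 stands at the limit of > 75000 nM in this assay, at which 1 of the 3 values shown sits. In this assay the step that the limit leaves unreadable from compound 3 to compound 4 is expected to be small, since the earlier methyl change left both compound 1 and compound 2 at a limit. Compound 4 is expected to give 80000 nM, most likely reported again only as a limit, within 40000 nM to 150000 nM.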

Compound 4, half-maximal cytotoxic concentration: > 15000 nM
Compound 4: only a limit was reported (the forecaster's own chance of this, stated with the estimate: 85%); the middle value is on the limit's open side.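

In this assay compound 4 gives > 15000 nM, a limit. Compound 3 gives > 75000 nM, also a limit, so no step can be read between compound 3 and compound 4. The compounds shown leave open whether methyl in place of hydrogen on an aromatic carbon changes cytotoxicity in either pair.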